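A few compounds are considered here, and "the series" means these few. Any claim that something is new, unique, unknown or untested is made for them only; others in the source may bear on it.

Measured in a functional assay on HCT-116 cells (Homo sapiens); a higher number here means a weaker inhibitor of growth, a lower number a stronger inhibitor of growth:

- compound 1 `Cc1cc(C)c2c(O)cc(-c3ccc(Cl)cc3)nc2n1` gives 14800 nM
- compound 2 `COc1cccc(-c2cc(=O)c3ccc(C)nc3[nH]2)c1` gives 46.8 nM
- compound 3 `COc1ccc(-c2cc(O)c3c(C)cc(C)nc3n2)cc1` gives 36300 nM

Compound 1 has the second highest number of the three. It sits fairly close to compound 3 and far above compound 2. The next compound to consider is compound 4 `Cc1ccnc2nc(-c3ccc(Cl)cc3)cc(O)c12`, which is related to compound 1 by a single change: hydrogen in place of methyl on an aromatic carbon. In other words, hydrogen stands in place of methyl on an aromatic carbon.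

For the measured compounds named here, only one measured step joins two compounds that differ in one place, a 2.5-fold higher number from compound 1 to compound 3 (0.39 log units; beyond the scatter). That step is modest, but it concerns the exchange of chloro for methoxy, not the methyl group, so it bears on the present change only as a rough guide to size. Compound 2, at 46.8 nM, shows that much lower numbers occur in this small set, but it differs from compound 1 in more than one place and cannot be tied to the methyl group. No step beyond the scatter is therefore expected in this assay, and any shift is expected to be slightly downward. The expected step is a 1.5-fold lower number from compound 1 to compound 4 (0.17 log units; within the scatter). For compound 4 the estimate is 10000 nM, with an expected range from 2500 nM to 35000 nM.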

Compound 4, concentration for 50% growth inhibition: 3720 nM
For compound 4 the middle estimate is 2.7-fold (0.43 log units) above the measured one; low and high end bracket the measured number.
By their numbers in this assay, from the lowest: compound 2; then compound 4; then compound 1; then compound 3.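

In this assay, for the compounds shown here, replacing the methyl group next to the ring nitrogen with hydrogen gives a 4.0-fold lower number from compound 1 to compound 4 (0.60 log units; beyond the scatter) and is the first measured change at this position of the core of compound 1. The position is therefore sensitive to this exchange, and the methyl group is not required for growth inhibition in this series, since the number falls without it. Going by these compounds alone, the direction also differs from that of the only earlier single change, at the chloro group, where a 2.5-fold higher number from compound 1 to compound 3 (0.39 log units; beyond the scatter) marks a rise, so the two sites of compound 1 have so far moved the number in opposite ways. Nothing available explains why removing the methyl group lowers the number.

The compounds shown leave open whether a larger group such as ethyl, or an amine or a fluoro group, placed at this same position would lower the number further or raise it again. They also leave open whether the remaining methyl group, meta to this position, can be replaced by hydrogen with a similar result, and whether the gain from this change would persist with methoxy in place of chloro.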